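Chain substituent variation on the shared enone benzoate core

The compounds below may be only part of what the source reports. "The series", "measured", "known", "first", "only" and "open" are said of these compounds alone.

Compound 3 `C/C=C(\COC(=O)c1ccccc1)C(=O)c1ccc(OC)cc1` carries a methyl on a double-bonded chain carbon bound to a double-bonded chain carbon. In a functional assay on A549 cells (Homo sapiens) for inhibition, read by XTT assay, with a stated time of 48 h (on this read-out lower numbers stand for stronger inhibition and higher numbers for weaker inhibition), compound 3 gives only a limit, > 100000 nM. Compound 1 `CCC(/C=C(\COC(=O)c1ccccc1)C(=O)c1ccc(OC)cc1)CC` likewise gives only a limit in this assay, > 100000 nM. Among the compounds with values here, compound 2 `COc1ccc(C(=O)/C(=C/C2CCCCC2)COC(=O)c2ccccc2)cc1` is the sole compound read as a number in this assay, 36000 nM. Two of the three values sit at the limit of > 100000 nM in this assay, at which 2 of the 3 values shown sit. The bearing steps are an at least 2.7-fold higher number from compound 2 to compound 3 (0.44 log units; beyond the scatter) and a step that the two limits leave unreadable from compound 1 to compound 3. Compound 4 `COc1ccc(C(=O)/C(=C/c2ccccc2Cl)COC(=O)c2ccccc2)cc1` differs from compound 3 by 2-chlorophenyl in place of methyl on a double-bonded chain carbon bound to a double-bonded chain carbon. The cyclohexyl of compound 2 went with the readable number 36000 nM, so for compound 4 a step down beyond the scatter is expected in this assay, the expected step being an at least 4.0-fold lower number from compound 3 to compound 4 (0.60 log units; beyond the scatter). Compound 4 is estimated at 25000 nM, range 5000 nM to 100000 nM.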

Compound 4, half-maximal inhibitory concentration: 20100 nM
Compound 4: middle estimate off by 1.2-fold (0.09 log units), on the high side; measured number inside the range.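

In this assay, 2-chlorophenyl at this place gives an at least 4.9-fold lower number from compound 3 to compound 4 (0.69 log units; beyond the scatter), and an at least 4.9-fold lower number from compound 1 to compound 4 (0.69 log units; beyond the scatter). Replacing the cyclohexyl gives a 1.8-fold lower number from compound 2 to compound 4 (0.25 log units; within the scatter), so the aromatic ring and the saturated ring cannot be told apart on this read-out, and a readable number at this place is not confined to cyclohexyl. Among the compounds shown, the two ring-bearing groups give numbers, whereas the methyl of compound 3 and the pentan-3-yl of compound 1 give only limits: the limit of > 100000 nM in this assay, at which 2 of the 4 values shown sit.

Open, on these data alone, is how an unsubstituted phenyl, or a phenyl carrying an amine or a carboxylic acid, would read at this place. As far as these compounds go, what the chlorine itself contributes is therefore also open.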